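A few compounds are considered here, and "the series" means these few. Any claim that something is new, unique, unknown or untested is made for them only; others in the source may bear on it.

Three compounds share one core and differ only in the group carried on a saturated chain carbon bound to an aromatic carbon. In an assay on CHO cells for displacement of a labelled ligand from adenosine receptor A1 (Homo sapiens), read by scintillation counting, tested at 1 uM (on this read-out higher numbers stand for more inhibition at the one concentration tested (going by the name of the read-out) and lower numbers for less inhibition), compound 1, `COc1ccc(Cc2nc(N)c3nn(-c4ccccc4)cc3n2)cc1`, gives 48%. Compound 2, `Cc1cccc(Cc2nc(N)c3nn(-c4ccccc4)cc3n2)c1`, gives 41% in this assay. Compound 3, `Nc1nc(Cc2cccc(Cl)c2)nc2cn(-c3ccccc3)nc12`, gives 32% in this assay, the lowest of the three numbers, though its gap to compound 2 lies within the scatter and only its gap to compound 1 lies beyond it.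

Compound 4, `Nc1nc(CCc2ccccc2)nc2cn(-c3ccccc3)nc12`, has not yet been measured. It differs from compound 3 in one place: benzyl in place of 3-chlorophenyl on a saturated chain carbon bound to an aromatic carbon. Among the compounds with values here, two measured steps bear on this change. The step of a number 9 percentage points lower from compound 2 to compound 3 (within the scatter) stayed within the scatter, while the step of a number 16 percentage points lower from compound 1 to compound 3 (beyond the scatter) was larger. Taking away the chloro is therefore expected to move the number little, or slightly upward, with an expected step of a number 8 percentage points higher from compound 3 to compound 4 (within the scatter). Compound 4 is estimated at 40% in this assay, with a range from 26% to 54%.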

Compound 4, a percentage reported as inhibition, at one concentration (the size of the read-out at that concentration, not a potency): 15%
Compound 4: middle estimate off by 25 percentage points, on the high side, outside the stated range (below it).
By their numbers in this assay, from the lowest: compound 4; then compounds 3, 2 and 1 (each within the scatter of the next, the first and the last beyond it).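

In this assay, phenethyl in place of the substituted benzyl groups gives a number 17 percentage points lower from compound 3 to compound 4 (beyond the scatter), a number 26 percentage points lower from compound 2 to compound 4 (beyond the scatter) and a number 33 percentage points lower from compound 1 to compound 4 (beyond the scatter). The earlier compounds shown here varied only the substituent on a benzyl group, whereas this result shows that the number at this position also responds to a change in the link to the ring, with all three steps lying beyond the scatter. No measurement shown here explains the drop.

Compound 4 also carries no substituent on its ring, so the effect of the phenethyl link cannot be separated from the loss of the substituent, and an unsubstituted benzyl group on the shared core would be needed to tell them apart. From the compounds shown here alone, how a longer chain such as phenylpropyl, or an amine on the chain, would read also remains open.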